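Removing the nitrile from a phenoxy proline amide

The source may hold more compounds than are shown below. What is called first, only, known or untested is meant among the compounds shown, and "the series" means these compounds.

Compound 1 `NC(=O)CN1CCCc2cc(OCc3ccccc3F)ccc2C1` and compound 2 `N#Cc1ccccc1Oc1ccc([C@H]2CC[C@@H](C(N)=O)N2)cc1` were both examined in an assay on HEK293 cells for inhibition of sodium channel protein type 3 subunit alpha (Homo sapiens), read by electrophysiology, with a stated time of 3.5 min; a higher number here means a weaker inhibitor, a lower number a stronger inhibitor. Compound 1 reached only the limit of the method, recorded as > 79400 nM. Compound 2 likewise returned a limit rather than a number, namely > 100000 nM. Compound 2 therefore stands at the limit of > 100000 nM in this assay, at which 1 of the 2 values shown sits, the upper edge of what this assay reports, and the other value shown is a limit as well, so no ranking between them can be drawn. Compound 3 `NC(=O)[C@@H]1CC[C@H](c2ccc(Oc3ccccc3)cc2)N1` is the unmeasured partner: hydrogen in place of cyano on an aromatic carbon. Within the data shown here, no measured pair shows this change, so its effect is unknown. With compound 2 already at a limit, the expected shift is a step that the limit leaves unreadable from compound 2 to compound 3, none beyond the scatter, and the outcome in this assay will most likely again be a limit. Compound 3 is accordingly estimated at 150000 nM, within 40000 nM to 600000 nM.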

Compound 3, half-maximal inhibitory concentration: 100000 nM
The estimate for compound 3 lay 1.5-fold (0.18 log units) above the measured number, within the range that was stated.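

With hydrogen in place of cyano on an aromatic carbon, ortho to a large group, this assay shows a number no higher from compound 2 to compound 3 (the limit leaves the size open). Compound 2 remains a limit of the assay, > 100000 nM. Compound 3 gives an actual number, 100000 nM, the only one among the three compounds shown, so the nitrile is not needed for whatever inhibition this series shows here, and taking it away leaves compound 3 a very weak inhibitor.

From the compounds shown here alone, how much the change moved the number cannot be read, since one end of the comparison is a limit: the limit of > 100000 nM in this assay, at which 1 of the 3 values shown sits. Whether an amine, a carboxylic acid or a methoxy group at this same carbon would bring a clearly lower number in this assay remains open.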